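Chlorophenyl position on the shared core

The source may report more compounds than this note shows. Statements on the series, on what has been measured and on what is new or still open speak of the compounds shown alone.

- compound 1 `Cc1ccc(-c2cc(-c3ccoc3)cc(-c3ccc(Cl)s3)n2)cc1`: 1170 nM
- compound 2 `Clc1ccc(-c2cc(-c3ccoc3)cc(-c3ccccc3Cl)n2)s1`: 1100 nM

In a functional assay on HCT-15 cells (Homo sapiens) for cytotoxicity, read by ELISA, with a stated time of 4 days (on this read-out higher numbers stand for weaker inhibition and lower numbers for stronger inhibition), compound 2 gives 1100 nM, and only compound 1 is available for comparison, with no separation between the two. Compound 3 `Clc1cccc(-c2cc(-c3ccoc3)cc(-c3ccc(Cl)s3)n2)c1` carries 3-chlorophenyl in place of 2-chlorophenyl on an aromatic carbon, next to the ring nitrogen: 3-chlorophenyl in place of 2-chlorophenyl on an aromatic carbon. Within the data shown here, the only measured step, a 1.1-fold lower number from compound 1 to compound 2 (0.03 log units; within the scatter), exchanged the group at this same place, so no step beyond the scatter is expected in this assay. The expected step is no change at the digits printed from compound 2 to compound 3 (within the scatter). The estimated value for compound 3 is 1100 nM, with an expected range of 500 nM to 2300 nM.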

Compound 3, half-maximal inhibitory concentration: 950 nM
Estimate against measurement, compound 3: 1.2-fold (0.06 log units) above; low and high end bracket the measured number.
By their numbers in this assay, from the lowest: compounds 3, 2 and 1 (each within the scatter of the next).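

In this assay, the chlorine position on the phenyl group at this place next to the ring nitrogen does not separate the compounds: 3-chlorophenyl in place of 2-chlorophenyl gives (a 1.2-fold lower number from compound 2 to compound 3 (0.06 log units; within the scatter)). Replacing 4-methylphenyl with 3-chlorophenyl gives (a 1.2-fold lower number from compound 1 to compound 3 (0.09 log units; within the scatter)), so all three aryl groups read alike here. Nothing available explains this flat result.

Open, going by these compounds, is whether an amine or a carboxylic acid on this phenyl group would move the number beyond the scatter. Also open, on these data alone, is whether the furan-3-yl or 5-chlorothiophen-2-yl group matters more than this position.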